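Adding Three Methoxy Groups to the Benzyl Arm

The source may report more compounds than this note shows. Statements on the series, on what has been measured and on what is new or still open speak of the compounds shown alone.

Three compounds share one core and differ only in the group attached to the amide-type nitrogen in the ring. In a functional assay on HeLa cells (Homo sapiens) for inhibition, read by MTT assay, with a stated time of 48 h (on this read-out lower numbers stand for stronger inhibition and higher numbers for weaker inhibition), compound 1 `COc1cc(-c2nc3cc(/C=C4\SC(=O)N(CC(=O)N5CCOCC5)C4=O)ccc3[nH]2)cc(OC)c1OC` gives 16300 nM. In this assay compound 2 `COc1cc(-c2nc3cc(/C=C4\SC(=O)N(CC(=O)N5CCCC5)C4=O)ccc3[nH]2)cc(OC)c1OC` gives 4780 nM, and compound 3 `COc1cc(-c2nc3cc(/C=C4\SC(=O)N(Cc5ccccc5)C4=O)ccc3[nH]2)cc(OC)c1OC` gives 950 nM, the lowest of the three numbers: the drop was a 17-fold lower number from compound 1 to compound 3 (1.23 log units; beyond the scatter) and a 5.0-fold lower number from compound 2 to compound 3 (0.70 log units; beyond the scatter).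

Compound 4 `COc1cc(CN2C(=O)S/C(=C\c3ccc4[nH]c(-c5cc(OC)c(OC)c(OC)c5)nc4c3)C2=O)cc(OC)c1OC` differs from compound 3 in one place: 3,4,5-trimethoxyphenyl in place of phenyl on a saturated chain carbon bound to an amide-type nitrogen in a ring. Within the data shown here, the measured steps of a 17-fold lower number from compound 1 to compound 3 (1.23 log units; beyond the scatter) and a 5.0-fold lower number from compound 2 to compound 3 (0.70 log units; beyond the scatter) both concern exchanging an amide-bearing group for the plain phenyl; no measured step alters the phenyl itself, so they bear on this change only in showing that the group in this place matters. Among the measured compounds shown here, with no direct precedent, the step is expected to stay small, a 1.2-fold lower number from compound 3 to compound 4 (0.07 log units; within the scatter), in either direction at most modest. In this assay compound 4 is expected to give about 800 nM, with a plausible range from 200 nM to 3200 nM.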

Compound 4, half-maximal inhibitory concentration: 2240 nM
Compound 4: the middle estimate sits 2.8-fold (0.45 log units) below what was measured, and the stated range covers the measured number.
By their numbers in this assay, from the lowest: compound 3; then compound 4; then compound 2; then compound 1.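

Until now only the kind of group at this place had changed, but here the phenyl itself is altered, and the three added methoxy groups give weaker inhibition in this assay, with a 2.4-fold higher number from compound 3 to compound 4 (0.37 log units; beyond the scatter) on this change. The 3,4,5-trimethoxyphenyl group still does better than either amide-bearing group, with a 2.1-fold lower number from compound 2 to compound 4 (0.33 log units; beyond the scatter) against the pyrrolidine amide and a 7.3-fold lower number from compound 1 to compound 4 (0.86 log units; beyond the scatter) against the morpholine amide, so a second aromatic arm at this place is not limited to plain phenyl. Nothing shown here explains why the methoxy groups weaken inhibition. Going by these compounds, whether a single methoxy group on the phenyl would behave like three remains open. So does the effect of an amine or a carboxylic acid on that ring, or of a longer chain carrying it.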